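Pivaloyloxy-piperidine analogue of a TRPV1 antagonist

The source may hold more compounds than are shown below. What is called first, only, known or untested is meant among the compounds shown, and "the series" means these compounds.

Measured compounds:
- compound 1, `CCCCNc1nc(C(F)(F)F)ccc1CNC(=O)C(C)c1ccc(NS(C)(=O)=O)c(F)c1`, 9.1 nM
- compound 2, `CC(C(=O)NCc1ccc(C(F)(F)F)nc1N1CCC(C(=O)c2ccc(F)cc2)CC1)c1ccc(NS(C)(=O)=O)c(F)c1`, 3.9 nM
- compound 3, `CC(C(=O)NCc1ccc(C(F)(F)F)nc1N1CCC(=O)CC1)c1ccc(NS(C)(=O)=O)c(F)c1`, 91 nM

In a functional assay on CHO-K1 cells for antagonist activity at transient receptor potential cation channel subfamily V member 1 (Homo sapiens), read by FLIPR (a higher number here means a weaker inhibitor, a lower number a stronger inhibitor), compound 2 gives the lowest number of the three, with compound 1 nearest and compound 3 furthest; both gaps are beyond the scatter. Compound 4, `CC(C(=O)NCc1ccc(C(F)(F)F)nc1N1CCC(OC(=O)C(C)(C)C)CC1)c1ccc(NS(C)(=O)=O)c(F)c1`, is not yet measured. It differs from compound 2 in one place: ((tert-butyl)carbonyl)oxy in place of (4-fluorophenyl)carbonyl on a saturated ring carbon.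

Among the measured compounds shown here, none of the measured steps changes exactly this group. For the measured compounds named here, the only single-point step known is a 10-fold higher number from compound 1 to compound 3 (1.00 log units; beyond the scatter), which shows that what sits on the core at that position can move this assay by a clear margin. Compound 2 and compound 3 share the six-membered ring with one nitrogen and differ only in what is attached to it, and their values lie far apart. A pivaloyloxy substituent keeps a large group on that ring carbon, so a moderate loss rather than a collapse is expected, a 3.6-fold higher number from compound 2 to compound 4 (0.56 log units; beyond the scatter). For compound 4 the expected value is 14 nM, with a range from 4 nM to 60 nM.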

Compound 4, inhibition constant: 2 nM
Beside the measured number, compound 4's estimate is 7.0-fold (0.85 log units) above it; measured number below the stated range.
By their numbers in this assay, from the lowest: compounds 4 and 2 (each within the scatter of the next); then compound 1; then compound 3.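

In this assay the exchange of (4-fluorophenyl)carbonyl for ((tert-butyl)carbonyl)oxy on the saturated ring carbon gives a 2.0-fold lower number from compound 2 to compound 4 (0.29 log units; within the scatter) and so does not separate the two groups. This is the first change shown at this ring carbon itself, and it shows that a substituent with no ring can stand there in place of one carrying a six-membered aromatic ring, with the number in this assay staying within the scatter. No measurement here accounts for this result.

As far as these compounds go, whether a hydroxyl group, an acetyloxy group or a dimethylamino group on the same carbon would hold the number in this assay stays open. So does the question of which part of ((tert-butyl)carbonyl)oxy, the tert-butyl group or the ester oxygen, matters to compound 4.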